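The compounds below may be only part of what the source reports. "The series", "measured", "known", "first", "only" and "open" are said of these compounds alone.

Going by the values given here, in a functional assay on SK-MEL-28 cells (Homo sapiens) for cytotoxicity, read by MTT assay, with a stated time of 72 h (a lower number here means a stronger inhibitor, a higher number a weaker inhibitor), compound 1 `COc1cc(/C=C/C=O)cc(OC)c1OC/C=C(\C)CCC=C(C)C` gives 26000 nM, the only actual number available in this small set. Compound 2 `CC(C)=CCC/C(C)=C/COc1ccc(/C=C/C(=O)O)cc1` gives > 100000 nM, which is a limit of the assay. Compound 3 `COc1cc(/C=C/C=O)cc(OC)c1OCC=C(C)C` departs from compound 1 by a single change, hydrogen in place of 3-methylbut-2-en-1-yl on a saturated chain carbon bound to a double-bonded chain carbon. Among the compounds with values here, no measured pair shows this change, so only a modest weakening in this assay, slightly beyond the scatter, is expected, an estimated step of a 2.3-fold higher number from compound 1 to compound 3 (0.36 log units; beyond the scatter). Compound 3 is estimated at 60000 nM, with an expected range of 20000 nM to 120000 nM.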

Compound 3, half-maximal inhibitory concentration: 32000 nM
Compound 3: middle estimate off by 1.9-fold (0.27 log units), on the high side; measured number inside the range.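

In this assay hydrogen in place of 3-methylbut-2-en-1-yl on a saturated chain carbon bound to a double-bonded chain carbon gives a 1.2-fold higher number from compound 1 to compound 3 (0.09 log units; within the scatter) and so stays within the scatter. Going by these compounds alone, this is the first measured pair at this position, and it shows that losing these five carbons leaves the number essentially unmoved. Nothing at hand bears on why this change has so small a step.

The compounds shown leave open whether an amine, a carboxylic acid or a longer chain at this place would shift the number beyond the scatter.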